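The compounds below may be only part of what the source reports. "The series", "measured", "known", "first", "only" and "open" are said of these compounds alone.

In an ADME assay on cells (Homo sapiens) for cytotoxicity, read by resazurin assay, with a stated time of 5 days (a lower number here means that less compound is tolerated, a higher number that more compound is tolerated), the series stands as follows:

- Compound 1 `COc1ccc(-c2nc(CC(=O)c3cccc(Cl)c3)nc3ccsc23)cn1` gives 30000 nM
- Compound 2 `COc1ccc(-c2nc(/C=C\c3cccc(Cl)c3)nc3ccsc23)cn1` gives 53000 nM
- Compound 3 `COc1ccc(-c2nc(COc3cccc(Cl)c3)nc3ccsc23)cn1` gives > 50000 nM as a limit

Compound 3 has no number, only a limit, which is the limit of > 50000 nM in this assay, at which 1 of the 3 values shown sits, and nothing more precise.

The unmeasured compound 4 `COc1ccc(-c2nc(CCc3cccc(Cl)c3)nc3ccsc23)cn1` carries this change from compound 3: 3-chlorobenzyl in place of 3-chlorophenoxy on a saturated chain carbon bound to an aromatic carbon with the rest of the molecule kept.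

Going by the values given here, one measured step bears on this place, an at least 1.6-fold higher number from compound 1 to compound 3 (0.22 log units; that floor lies within the scatter) and it rests on that limit. Compound 2 at 53000 nM and compound 1 at 30000 nM lie in the same region, with a different group at this place in each.

On these values no step beyond the scatter is expected in this assay and no direction is favoured. The estimated step is an at least 1.1-fold lower number from compound 3 to compound 4 (0.04 log units; that floor lies within the scatter) and it is expected to stay small. Compound 4 is estimated at 45000 nM with an expected range from 20000 nM to 90000 nM and a reading at the limit would not be surprising.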

Compound 4, half-maximal cytotoxic concentration: > 50000 nM
Compound 4: only a limit was reported; the forecaster's own chance of this, stated with the estimate: 40%; middle value at least 1.1-fold (0.04 log units) from the limit.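

In this assay compound 4 is reported only as a limit, > 50000 nM. Going by these compounds alone, with limits now standing for both 3-chlorophenoxy and 3-chlorobenzyl on this saturated chain carbon, replacing the oxygen-linked group with the all-carbon one does not bring the reading down to a measurable number: the limit of > 50000 nM in this assay, at which 2 of the 4 values shown sit. The one readable new step is an at least 1.6-fold higher number from compound 1 to compound 4 (0.22 log units; that floor lies within the scatter), and the step between the two limits cannot be read.

Still open, going by these compounds, is how an amine or a carboxylic acid at this place would read in this assay, and whether any group here can give a step beyond the scatter. Also open, on these data alone, is how compound 3 and compound 4 compare past the limit they share.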